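Alkoxy swaps on a shared core at the A3 receptor

The source may report more compounds than this note shows. Statements on the series, on what has been measured and on what is new or still open speak of the compounds shown alone.

compound 1 `CCCOc1ccc(-c2cn3c(=O)n(-c4ccccc4)nc3c(N)n2)cc1`: > 30000 nM
compound 2 `C=CCOc1ccc(-c2cn3c(=O)n(-c4ccccc4)nc3c(N)n2)cc1`: "not determined" (no result reported)
compound 3 `C#CCOc1ccc(-c2cn3c(=O)n(-c4ccccc4)nc3c(N)n2)cc1`: > 30000 nM

In an assay on cells for displacement of a labelled ligand from adenosine receptor A3 (Homo sapiens), read by scintillation counting, with a stated time of 3 h (a lower number here means a stronger inhibitor, a higher number a weaker inhibitor), compound 1 gives > 30000 nM, which is a limit of the assay and not a number. Compound 3 gives > 30000 nM in this assay, again only a limit. For compound 2 the entry in this assay reads "not determined" (no result reported). Within the data shown here, the only measured step, a step that the two limits leave unreadable from compound 1 to compound 3, therefore has no readable size; both ends sit at the limit of > 30000 nM in this assay, at which 2 of the 3 values shown sit. Compound 3 thus stands at the limit, with no numbered value among the three compounds. Compound 4 `CC(C)Oc1ccc(-c2cn3c(=O)n(-c4ccccc4)nc3c(N)n2)cc1` differs from it by isopropyl in place of propargyl on an oxygen on an aromatic ring. Among the measured compounds shown here, no measured step bears on this change, so no shift beyond the scatter is expected, and the step that the limit leaves unreadable from compound 3 to compound 4 is an estimate only. Compound 4 is expected at 40000 nM, within 10000 nM to 150000 nM.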

Compound 4, inhibition constant: > 30000 nM
Compound 4 ended at the assay's limit (the forecaster's own chance of this, stated with the estimate: 80%); the middle value does not contradict the limit.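

No size can be read for the steps linking compound 4 to compound 1 and compound 3, because all three compounds rest on one assay limit: the limit of > 30000 nM in this assay, at which 3 of the 4 values shown sit.

Which group on the oxygen, if any, would give a numbered value on the shared core stays open.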